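Aryl hydrazides of glutamic acid: adding a second ring methyl

A few compounds are considered here, and "the series" means these few. Any claim that something is new, unique, unknown or untested is made for them only; others in the source may bear on it.

compound 1 `Cc1ccccc1NNC(=O)CC[C@H](N)C(=O)O` 6.24 ug/mL
compound 2 `Cc1ccc(NNC(=O)CC[C@H](N)C(=O)O)cc1` 9.99 ug/mL
compound 3 `N[C@@H](CCC(=O)NNc1ccc(F)cc1)C(=O)O` 13.8 ug/mL

In a functional assay, read by spectrophotometry, with a stated time of 30 min (a higher number here means a weaker inhibitor, a lower number a stronger inhibitor), compound 2 gives 9.99 ug/mL, the second highest of the three numbers. Compound 3 gives 13.8 ug/mL and compound 1 gives 6.24 ug/mL, both within the scatter of compound 2. Compound 4 `Cc1ccc(NNC(=O)CC[C@H](N)C(=O)O)c(C)c1` differs from compound 2 by methyl in place of hydrogen on an aromatic carbon. For the measured compounds named here, the only measured step, a 1.4-fold higher number from compound 2 to compound 3 (0.14 log units; within the scatter), concerns a different group at a different place on the ring and shows only that a small change there moved the number little. Compound 1, which carries a methyl ortho to the large group but no other ring methyl, gives 6.24 ug/mL, within the scatter of compound 2. No step beyond the scatter is therefore expected in this assay. The expected step is a 1.3-fold lower number from compound 2 to compound 4 (0.12 log units; within the scatter). Compound 4 is estimated at 7.5 ug/mL, range 3.5 ug/mL to 16 ug/mL.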

Compound 4, half-maximal inhibitory concentration: 15.8 ug/mL
Compound 4: middle estimate off by 2.1-fold (0.32 log units), on the low side, within the range that was stated.
By their numbers in this assay, from the lowest: compounds 1, 2, 3 and 4 (each within the scatter of the next, the first and the last beyond it).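

In this assay, methyl in place of hydrogen ortho to a large group and meta to a methyl group gives a 1.6-fold higher number from compound 2 to compound 4 (0.20 log units; within the scatter) and so cannot be told from repeat scatter at this position. The second listed step, a 2.5-fold higher number from compound 1 to compound 4 (0.40 log units; beyond the scatter), is the first in the series to pass the scatter, and it shows that a second ring methyl brings no gain over the single methyl of compound 1. No measurement here bears on why the number moves.

Still open, going by these compounds, is whether an ethyl, a methoxy or a chlorine at this position departs from compound 2 beyond the scatter. Also open, on these data alone, is whether an amine on the ring shifts the number in the other direction.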